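This account rests on a few compounds, and the source may have more. Where it says the series, first, only, none or still open, it means among the compounds named here.

In a functional assay on NCI-H322M cells (Homo sapiens) for inhibition, read by sulforhodamine B assay, with a stated time of 48 h, tested at 10 uM (on this read-out higher numbers stand for a weaker effect at the one concentration tested and lower numbers for a stronger effect), compound 3 `O=C(Nc1cccc(-n2cc(-c3ccncc3)c(-c3cc(O)cc(Cl)c3)n2)c1)Nc1ccc(Cl)c(Cl)c1` gives 19.5%, which places it at the low end of the three compounds: compound 1 `COc1cc(Cl)cc(-c2nn(-c3cccc(NC(=O)Nc4cccc(C(F)(F)F)c4)c3)cc2-c2ccncc2)c1` gives 26.2%, a number within the scatter of compound 3, while compound 2 `COc1cc(Cl)cc(-c2nn(-c3cccc(NC(=O)c4ccc(Cl)c(Cl)c4)c3)cc2-c2ccncc2)c1` gives 84.6%, far above both. Within the data shown here, the one measured step, a number 58.4 percentage points higher from compound 1 to compound 2 (beyond the scatter), concerns the amide end of the molecule. Compound 4 `COc1cc(Cl)cc(-c2nn(-c3cccc(NC(=O)Nc4ccc(Cl)c(Cl)c4)c3)cc2-c2ccncc2)c1` differs from compound 3 elsewhere: methyl in place of hydrogen on an oxygen on an aromatic ring. Among the measured compounds shown here, no measured pair shows this hydroxy-to-methoxy change, so nothing here says how it should shift the read-out, and the expectation for compound 4 is a step of about a number 4.5 percentage points higher from compound 3 to compound 4 (within the scatter), not beyond the scatter. Compound 4 is therefore estimated to give 24%, within a range from 10% to 45%.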

Compound 4, a percentage reported as activity, at one concentration (the size of the read-out at that concentration, not a potency): 32.3%
Beside the measured number, compound 4's estimate is 8.3 percentage points below it; the range from low to high includes it.
By their numbers in this assay, from the lowest: compounds 3, 1 and 4 (each within the scatter of the next, the first and the last beyond it); then compound 2.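

In this assay, among these compounds, the first reading for this position is a number 12.8 percentage points higher from compound 3 to compound 4 (beyond the scatter), so methyl in place of hydrogen on this oxygen modestly weakens the effect. With methoxy fixed, the other end gives two different answers: a number 52.3 percentage points lower from compound 2 to compound 4 (beyond the scatter) when the amino link is added on the carbonyl carbon, but a number 6.1 percentage points higher from compound 1 to compound 4 (within the scatter) when 3,4-dichlorophenyl replaces 3-(trifluoromethyl)phenyl. No measurement here explains these shifts. On these data alone, what remains open is how a longer chain such as ethoxy on this oxygen, or an amine in place of the hydroxy, would read out.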